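This account rests on a few compounds, and the source may have more. Where it says the series, first, only, none or still open, it means among the compounds named here.

Measured in a functional assay on MDA-MB-231 cells (Homo sapiens) for inhibition, read by MTT assay; a lower number here means a stronger inhibitor of growth, a higher number a weaker inhibitor of growth:
- compound 1 `CC1=C(/C=C/C(C)=C/C=C/C(C)=C\C(=O)Nc2ccc(O)cc2)C(C)(C)CCC1n1ccnc1`: 13100 nM
- compound 2 `CC1=C(/C=C/C(C)=C/C=C/C(C)=C\C(=O)Nc2cccc(F)c2)C(C)(C)CCC1n1ccnc1`: 8510 nM
- compound 3 `CC1=C(/C=C/C(C)=C/C=C/C(C)=C\C(=O)NCc2ccc(O)cc2)C(C)(C)CC=C1c1cncnc1`: 11500 nM

Compound 2 has no distinct place among these three values, since its gaps to compound 1 and compound 3 both lie within the scatter. The next change leads to compound 4 `CC1=C(/C=C/C(C)=C/C=C/C(C)=C\C(=O)NCc2ccc(O)cc2)C(C)(C)CCC1n1ccnc1`, with 4-hydroxybenzyl in place of 3-fluorophenyl on an amide-type nitrogen.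

Within the data shown here, one measured step bears on this change: a 1.5-fold lower number from compound 1 to compound 2 (0.19 log units; within the scatter). It exchanges 4-hydroxyphenyl for 3-fluorophenyl at the same amide-type nitrogen and stays within the scatter. Compound 4 also shares the 4-hydroxybenzyl group with compound 3, which gives 11500 nM, although the two structures differ elsewhere. Neither comparison points to a shift in either direction, so no change beyond the scatter is expected in this assay. The expected size is a 1.3-fold higher number from compound 2 to compound 4 (0.11 log units; within the scatter). For compound 4 the estimated value is 11000 nM. The expected range for compound 4 runs from 5500 nM to 22000 nM.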

Compound 4, concentration for 50% growth inhibition: 2230 nM
Beside the measured number, compound 4's estimate is 4.9-fold (0.69 log units) above it; the whole stated range lies above it.
By their numbers in this assay, from the lowest: compound 4; then compounds 2, 3 and 1 (each within the scatter of the next).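

In this assay, among these compounds, the amide-type nitrogen now proves sensitive to its substituent: the change to 4-hydroxybenzyl gives a 3.8-fold lower number from compound 2 to compound 4 (0.58 log units; beyond the scatter) and is the first step in this set beyond the scatter. With the hydroxyl kept, 4-hydroxybenzyl in place of 4-hydroxyphenyl gives a 5.9-fold lower number from compound 1 to compound 4 (0.77 log units; beyond the scatter), so the benzyl form carries a shift that the exchange of aryl groups, at a 1.5-fold lower number from compound 1 to compound 2 (0.19 log units; within the scatter), did not show. No evidence at hand accounts for these steps.

As far as these compounds go, it remains open whether the shift depends on the hydroxyl or on the benzyl form alone, a question that an unsubstituted benzyl or a 3-fluorobenzyl group on the same nitrogen would settle. A 2-phenylethyl chain there would show whether the trend continues with further lengthening.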